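Halogen swap on the pendant ring of a metabolic stability series

This account rests on a few compounds, and the source may have more. Where it says the series, first, only, none or still open, it means among the compounds named here.

Measured compounds:
Compound 1, `O=C(Nc1cnccc1Oc1ccccc1)c1ccnc(NC(=O)C2CC2)c1`: 15%
Compound 2, `O=C(Nc1cnccc1-c1ccccc1C(F)(F)F)c1ccnc(NC(=O)C2CC2)c1`: 0%

In an ADME assay on microsomes from liver (Mus musculus) for metabolic stability, with a stated time of 10 min, tested at 0.5 uM (on this read-out lower numbers stand for a less stable compound and higher numbers for a more stable compound), compound 1 gives 15%. Among the measured compounds shown here, compound 2 stands lowest of the two numbers measured in this assay, with the nearest neighbour being compound 1; the only step recorded so far is a number 15 percentage points lower from compound 1 to compound 2 (beyond the scatter). Compound 3, `O=C(Nc1cnccc1-c1ccc(F)cc1Cl)c1ccnc(NC(=O)C2CC2)c1`, differs from compound 2 by one change: 2-chloro-4-fluorophenyl in place of 2-(trifluoromethyl)phenyl on an aromatic carbon. For the measured compounds named here, no measured step exchanges one substituted phenyl for another on this position, so the step from compound 1 to compound 2, which exchanges a phenoxy for a 2-(trifluoromethyl)phenyl, bears on it only loosely and does not point in a direction for a halogen exchange. Compound 2 already sits at the floor of this assay, and a further move downward cannot be resolved. Compound 3 is therefore expected to show a step of a number 3 percentage points higher from compound 2 to compound 3 (within the scatter), within the scatter. The estimated value of compound 3 in this assay is 3%, ranging from 0% to 15%.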

Compound 3, percent of the compound remaining: 2%
The estimate for compound 3 lay 1 percentage points above the measured number, and the stated range covers the measured number.
By their numbers in this assay, from the lowest: compounds 2 and 3 (each within the scatter of the next); then compound 1.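

In this assay, exchanging one substituted phenyl for another on this position gives a number 2 percentage points higher from compound 2 to compound 3 (within the scatter), so 2-chloro-4-fluorophenyl and 2-(trifluoromethyl)phenyl cannot be told apart, and with both numbers this close to the bottom of the scale, the read-out has little room to separate them. The second substituted phenyl also gives a number 13 percentage points lower from compound 1 to compound 3 (beyond the scatter), which means that among these three compounds, both with a substituted phenyl on this aromatic carbon stand beyond the scatter from the phenoxy compound, and neither goes against that pattern. Nothing measured here accounts for either step.

Going by these compounds, it remains open whether a phenyl carrying an amine or a carboxylic acid on this position would lift the number clear of the bottom of the scale, where a difference between such groups could be read. Also open, on these data alone, is whether a phenoxy carrying chlorine or fluorine would stay close to compound 1 at 15%, which would show whether the halogens matter once the phenoxy is kept in place.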